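Adding a Second Methyl to the Sulfonamide Aryl Ring

This account rests on a few compounds, and the source may have more. Where it says the series, first, only, none or still open, it means among the compounds named here.

Compound 1 `Cc1ccccc1NS(=O)(=O)c1ccc(N2CCNC2=O)cc1` and compound 2 `O=C1NCCN1c1ccc(S(=O)(=O)Nc2cccc(Oc3ccccc3)c2)cc1` share a core and were both tested in a functional assay on M21 cells (Homo sapiens) for antiproliferative activity, read by sulforhodamine B assay, with a stated time of 48 h; a higher number here means a weaker inhibitor, a lower number a stronger inhibitor. Compound 1 gives 150 nM, the higher of the two numbers, and compound 2 gives 83 nM; the two values sit within the usual scatter, so neither is set apart. Compound 3 `Cc1cccc(NS(=O)(=O)c2ccc(N3CCNC3=O)cc2)c1C` differs from compound 1 by methyl in place of hydrogen on an aromatic carbon, which read one bond further out is 2-methylphenyl to 2,3-dimethylphenyl. Going by the values given here, no measured pair shows such a change, so a step no larger than the scatter, in no clear direction, is expected. Compound 3 is expected to give 150 nM, between 60 nM and 400 nM. The expected step is no change at the digits printed from compound 1 to compound 3 (within the scatter).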

Compound 3, half-maximal inhibitory concentration: 110 nM
The estimate for compound 3 lay 1.4-fold (0.13 log units) above the measured number; the measured number falls inside the stated range.
By their numbers in this assay, from the lowest: compounds 2, 3 and 1 (each within the scatter of the next).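

In this assay, methyl in place of hydrogen on this aromatic carbon, ortho to a methyl group, gives a 1.4-fold lower number from compound 1 to compound 3 (0.13 log units; within the scatter), the first step read at this position. The 2,3-dimethylphenyl compound therefore stays within the scatter of the 2-methylphenyl compound, so this one added methyl leaves the number effectively unmoved. No supporting evidence bears on this result. As far as these compounds go, whether an amine, a carboxylic acid or a longer chain on this carbon would also stay within the scatter remains open.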